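Carboxy to hydroxycarbamoyl-cyclopropyl on a shared aromatic core

The compounds below may be only part of what the source reports. "The series", "measured", "known", "first", "only" and "open" are said of these compounds alone.

Measured compounds:
- compound 1, `O=C(O)c1ccc(NCc2cccc(Oc3ccccc3)c2)cc1`: < 10000 nM
- compound 2, `Cc1nc(-c2ccc(C(F)(F)F)cc2)sc1CNc1ccc(CCCC(=O)O)cc1`: < 10000 nM
- compound 3, `Cc1nc(-c2ccc(C(F)(F)F)cc2)sc1CNc1ccc(/C=C/C(=O)O)cc1`: 36.3 nM

In a functional assay on CHO cells for agonist activity at Free fatty acid receptor 1 (Homo sapiens) (a higher number here means that more compound is needed for the effect, a lower number that less compound is needed), compound 1 gives < 10000 nM, and this value is a limit of the assay rather than a number. Compound 2 in this assay likewise gives < 10000 nM, again a limit. Compound 3 gives 36.3 nM in this assay. Going by the values given here, the one step between compounds that differ in a single place, a step that the limit leaves unreadable from compound 2 to compound 3, cannot be read in size, because of the limit of < 10000 nM in this assay, at which 2 of the 3 values shown sit.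

Compound 4, `O=C(NO)[C@H]1C[C@@H]1c1ccc(NCc2cccc(Oc3ccccc3)c2)cc1`, differs from compound 1 in one place: 2-(hydroxycarbamoyl)cyclopropyl in place of carboxy on an aromatic carbon. Among the compounds with values here, no measured step touches the carboxy group itself, and the only measured step is unreadable, so nothing here sets a size or direction for this change. Compound 1 is known only as a limit, so the step to compound 4 cannot be anchored either. Compound 4 is therefore expected at 1500 nM in this assay, within 150 nM to 10000 nM. The step that the limit leaves unreadable from compound 1 to compound 4 is estimated only loosely, with a fair chance that a limit is again all that is seen.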

Compound 4, half-maximal effective concentration: 14.8 nM
The estimate for compound 4 lay 100-fold (2.01 log units) above the measured number; the measured number lies below the stated range.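

No new step can be read: compound 1 stands only as a limit, so the change to compound 4 has no readable size, because of this: the limit of < 10000 nM in this assay, at which 2 of the 4 values shown sit.

The compounds shown leave open how large this change is on the shared core, and whether 2-(hydroxycarbamoyl)cyclopropyl in place of carboxy would act alike on other cores.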